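The compounds below may be only part of what the source reports. "The series", "measured", "known", "first", "only" and "open" are said of these compounds alone.

Working notes on the series.

Compound 3 `CCCCCCCCCCCCCCNC(=O)[C@@H](NC(=O)c1ccco1)[C@@H](C)O` is the furoyl amide with a tetradecyl chain, and in a functional assay on A-431 cells (Homo sapiens) for cytotoxicity, read by MTT assay, with a stated time of 48 h (on this read-out higher numbers stand for weaker inhibition and lower numbers for stronger inhibition), compound 3 gives 190000 nM, the highest number among the three measured compounds. Its nearest neighbour is compound 2 `CCCCCCCCCCCCNC(=O)[C@@H](NC(=O)c1ccco1)[C@@H](C)O`, the dodecyl analogue, which in this assay gives 92400 nM; the furthest is compound 1 `CCCCCCCCCCCCCCCCCCNC(=O)[C@@H](N)[C@@H](C)O`, the free amine with an octadecyl chain, which in this assay gives 21300 nM.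

Compound 4 `CCCCCCCCCCCCCCCCCCNC(=O)[C@@H](NC(=O)c1ccco1)[C@@H](C)O` carries the furoyl amide of compound 3 together with the octadecyl chain of compound 1. Against compound 3 the difference is butyl in place of hydrogen on a saturated chain carbon, ten or more bonds along the chain from an amide-type nitrogen. Within the data shown here, the only measured step of the same kind is a 2.1-fold higher number from compound 2 to compound 3 (0.31 log units; beyond the scatter), a chain lengthening that raised the number modestly. The change to compound 4 continues in the same direction and is larger, so a further rise is expected, of uncertain size; no pairing with compound 1 is available as a step, since that compound differs at the amine as well. The expected step is a 1.6-fold higher number from compound 3 to compound 4 (0.20 log units; within the scatter). For compound 4 the estimate in this assay is therefore 300000 nM, with a likely range of 110000 nM to 800000 nM.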

Compound 4, half-maximal inhibitory concentration: 19900 nM
For compound 4 the middle estimate is 15-fold (1.18 log units) above the measured one; the measured number lies below the stated range.
By their numbers in this assay, from the lowest: compounds 4 and 1 (each within the scatter of the next); then compound 2; then compound 3.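

The chain position does not respond in one direction: a 2.1-fold higher number from compound 2 to compound 3 (0.31 log units; beyond the scatter) is followed by a 9.5-fold lower number from compound 3 to compound 4 (0.98 log units; beyond the scatter), so the butyl extension reverses the earlier rise, and the whole hexyl extension gives a 4.6-fold lower number from compound 2 to compound 4 (0.67 log units; beyond the scatter). Among these furoyl amides, compound 3 therefore has the highest number, and the relation between chain length and number is not monotonic. At the octadecyl chain, the amine change gives a 1.1-fold lower number from compound 1 to compound 4 (0.03 log units; within the scatter), so (furan-2-yl)carbonyl in place of hydrogen on the amine nitrogen leaves the two compounds within the scatter of each other.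

No evidence at hand bears on this result.

As far as these compounds go, whether the number keeps falling with a longer chain such as icosyl remains open, as does the behaviour of a decyl chain. Also open, from the compounds shown here alone, is whether the free amine matches the furoyl amide with a dodecyl or tetradecyl chain, or whether an acetyl group on that nitrogen behaves likewise.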